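Swapping the piperazine substituent: a pyridine ring moves closer

A few compounds are considered here, and "the series" means these few. Any claim that something is new, unique, unknown or untested is made for them only; others in the source may bear on it.

Measured so far:
Compound 1 `CCN1CCN(S(=O)(=O)CCCN2CCC(CNC(=O)c3cccc4c3OCCO4)CC2)CC1` gives 0.0501 nM in an assay on isolated protein for inhibition of 5-hydroxytryptamine receptor 4 (Homo sapiens); a lower number here means a stronger inhibitor, a higher number a weaker inhibitor.
Compound 2 `O=C(NCC1CCN(CCCS(=O)(=O)N2CCN(Cc3cccnc3)CC2)CC1)c1cccc2c1OCCO2` gives 0.159 nM in this assay.
Compound 3 `CC(C)S(=O)(=O)N1CCN(S(=O)(=O)CCCN2CCC(CNC(=O)c3cccc4c3OCCO4)CC2)CC1` gives 0.126 nM in this assay.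

All three compounds share one core and differ only in the group on an amine nitrogen in a ring. Compound 2 has the highest number of the three: the step from compound 1 to compound 2 is a 3.2-fold higher number from compound 1 to compound 2 (0.50 log units; beyond the scatter), whereas compound 2 and compound 3 sit within the scatter of each other, a 1.3-fold lower number from compound 2 to compound 3 (0.10 log units; within the scatter).

Compound 4 `O=C(NCC1CCN(CCCS(=O)(=O)N2CCN(c3ccccn3)CC2)CC1)c1cccc2c1OCCO2` is the next step from compound 2. The change is pyridin-2-yl in place of (pyridin-3-yl)methyl on an amine nitrogen in a ring. Going by the values given here, two measured steps touch this same position. One, from compound 1 to compound 2, was modest; the other, from compound 2 to compound 3, lay within the scatter. Changing this group has therefore never moved the number far. A step within the scatter, or at most a modest one toward a lower number, is expected here, a 1.2-fold lower number from compound 2 to compound 4 (0.09 log units; within the scatter). Compound 4 is expected to give 0.13 nM, within a range from 0.04 nM to 0.5 nM.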

Compound 4, inhibition constant: 0.251 nM
The estimate for compound 4 lay 1.9-fold (0.29 log units) below the measured number; measured number inside the range.
By their numbers in this assay, from the lowest: compound 1; then compounds 3, 2 and 4 (each within the scatter of the next).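

Putting pyridin-2-yl in place of (pyridin-3-yl)methyl on this amine nitrogen gives a step within the scatter (a 1.6-fold higher number from compound 2 to compound 4 (0.20 log units; within the scatter)), so this position accepts an aromatic ring with or without the methyl part of the group. Compound 4 also stays within the scatter of the isopropylsulfonyl compound (a 2.0-fold higher number from compound 3 to compound 4 (0.30 log units; within the scatter)), so compounds 2, 3 and 4 cannot be ranked by this change in this assay. Compound 1, with its ethyl group, remains the strongest inhibitor of the four, and its step to the new compound is modest but beyond the scatter (a 5.0-fold higher number from compound 1 to compound 4 (0.70 log units; beyond the scatter)).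

No available evidence explains these differences. On these data alone, this step removes the methyl part and also changes pyridin-3-yl to pyridin-2-yl, so the two changes stay unseparated, and it remains open how pyridin-3-yl itself or a plain benzyl group on this nitrogen would compare.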